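The source may report more compounds than this note shows. Statements on the series, on what has been measured and on what is new or still open speak of the compounds shown alone.

Working notes on the series. The shared core appears in compound 1 `O=c1nc(N2CCC(c3ccccc3)CC2)sc2c([N+](=O)[O-])cc(C(F)(F)F)cc12`, compound 2 `C[C@H]1COC2(CCN(c3nc(=O)c4cc(C(F)(F)F)cc([N+](=O)[O-])c4s3)CC2)O1`, compound 3 `Cc1ccc(CNc2nc(=O)c3cc(C(F)(F)F)cc([N+](=O)[O-])c3s2)n1C` and the not yet measured compound 4 `COC(=O)C1CN(c2nc(=O)c3cc(C(F)(F)F)cc([N+](=O)[O-])c3s2)CCC12OC[C@H](C)O2`. All results so far come from an ADME assay on HeLa cells (Homo sapiens) for cytotoxicity, with a stated time of 72 h; on this read-out lower numbers stand for higher toxicity in this test and higher numbers for lower toxicity in this test. In this assay compound 1 gives only a limit of > 50000 nM. In this assay compound 2 likewise gives only a limit, > 50000 nM. In this assay, going by the values given here, compound 3 gives 48000 nM, the single number in the set, and it lies close to the limit of > 50000 nM in this assay, at which 2 of the 3 values shown sit. Compound 2 thus stands at the limit rather than at a number, sharing that limit with compound 1, and its value and that of compound 3 sit within the usual scatter of one another.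

Compound 4 differs from compound 2 in one place: methoxycarbonyl in place of hydrogen on a saturated ring carbon. Among the compounds with values here, no step between two measured compounds covers this kind of change, so its effect cannot be read from the numbers at hand. Since compound 2 reaches only the limit > 50000 nM in this assay, the expected step that the limit leaves unreadable from compound 2 to compound 4 is none beyond the scatter. Compound 4 is accordingly expected to give about 60000 nM in this assay, within a range from 25000 nM to 150000 nM, most probably again as a limit only.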

Compound 4, half-maximal cytotoxic concentration: 36000 nM
Estimate against measurement, compound 4: 1.7-fold (0.22 log units) above; low and high end bracket the measured number.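

Methoxycarbonyl in place of hydrogen on a saturated ring carbon, two ring bonds from the ring nitrogen, gives in this assay an at least 1.3-fold lower number from compound 2 to compound 4 (0.14 log units; that floor lies within the scatter). With this group on that carbon, compound 4 gives a number, 36000 nM, and not a limit, so this spiro-bearing ring now has one readable value in this assay. Compound 2 stands at a limit, > 50000 nM, so only a floor of the step can be read, and that floor alone does not establish a change beyond the usual scatter: the limit of > 50000 nM in this assay, at which 2 of the 4 values shown sit.

Going by these compounds, the true size of the step therefore stays open, and a number for a close analogue of compound 2 that falls inside the range of this assay would be needed to settle it. Also open, on these data alone, is whether the value of compound 4 belongs to methoxycarbonyl itself or would hold for other groups on this saturated ring carbon, such as a carboxylic acid, an amine or a longer chain.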